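Swapping an aryl group for pyrrole on the shared core

This account rests on a few compounds, and the source may have more. Where it says the series, first, only, none or still open, it means among the compounds named here.

Measured in a functional assay on KYSE-70 cells for antiproliferative activity against KYSE-70 cell line (Homo sapiens), read by MTT assay, with a stated time of 72 h; on this read-out lower numbers stand for stronger inhibition and higher numbers for weaker inhibition:
compound 1 `C#CCSc1nc(Sc2nccs2)c(C#N)c(-c2ccc(Br)cc2)n1`: 10900 nM
compound 2 `C#CCSc1nc(Sc2nccs2)c(C#N)c(-c2ccc(C)cc2)n1`: 4300 nM

In this assay, compound 2 has the lower of the two numbers, at 4300 nM. Going by the values given here, the only measured step is a 2.5-fold lower number from compound 1 to compound 2 (0.40 log units; beyond the scatter). Compound 3 `C#CCSc1nc(Sc2nccs2)c(C#N)c(-c2ccc[nH]2)n1` keeps the shared core but differs in one group: 1H-pyrrol-2-yl in place of 4-methylphenyl on an aromatic carbon. Here 1H-pyrrol-2-yl stands in place of 4-methylphenyl, so a five-membered aromatic ring with 1 hetero atom replaces a six-membered aromatic ring of carbon only.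

The measured step bears on this only loosely. It exchanged bromo for methyl on the aromatic ring, whereas compound 3 loses that whole ring. Among the compounds with values here, no measured compound shows what such a replacement does, so the direction is uncertain and the range must be wide. Within the data shown here, since compound 2 has the lowest number so far, at 4300 nM, a modest move to a higher number is the more cautious expectation. The expected change is a 2.1-fold higher number from compound 2 to compound 3 (0.32 log units; beyond the scatter). For compound 3 the estimated value is 9000 nM, with an expected range from 2500 nM to 30000 nM.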

Compound 3, half-maximal inhibitory concentration: > 20000 nM
Compound 3 was reported as a limit; the forecaster's own chance of this, stated with the estimate: 7%; middle value at least 2.2-fold (0.34 log units) away from the limit.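

Compound 3 is reported only as a limit of the assay, not as an exact number, in this assay: the limit of > 20000 nM in this assay, at which 1 of the 3 values shown sits. Even so, that limit sets a floor: putting 1H-pyrrol-2-yl in place of 4-methylphenyl on this aromatic carbon gives an at least 4.6-fold higher number from compound 2 to compound 3 (0.66 log units; beyond the scatter), so at this position the nature of the whole ring can move the number, not only the small group on it, and here the move is towards weaker inhibition. Set against the bromo compound, the same change gives an at least 1.8-fold higher number from compound 1 to compound 3 (0.26 log units; that floor lies within the scatter), and since that floor lies within the scatter, it fixes no order between those two compounds.

The compounds shown leave open which part of the change matters: the smaller ring, the ring nitrogen with its hydrogen, or the loss of the group that the six-membered ring carried. A plain phenyl, a thiophene ring or a pyrrole with a methyl on its nitrogen at this position would help to separate these possibilities, and an exact value for compound 3 would show how large the step really is.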